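The source may hold more compounds than are shown below. What is called first, only, known or untested is meant among the compounds shown, and "the series" means these compounds.

Measured compounds in a functional assay on PC-3 cells (Homo sapiens) for antiproliferative activity, read by MTT assay, tested at 5 uM; a lower number here means a weaker effect, a higher number a stronger effect of the compound at the concentration tested:
compound 1 `COc1cc(C(=O)N/N=C/c2ccc(F)c(F)c2)cc(OC)c1OC` gives 43.7%;
compound 2 `COc1cc(C2=NN(C(C)=O)C(c3ccc(F)c(F)c3)O2)cc(OC)c1OC` gives 46.9%;
compound 3 `COc1cc(C2=NN(C(C)=O)C(c3ccc(Cl)c([N+](=O)[O-])c3)O2)cc(OC)c1OC` gives 61.4%.

Compound 1 holds the lowest of the three numbers. Its gap to compound 2 lies within the scatter, so no order between these two can be read; compound 3 sits beyond the scatter above compound 1. For the measured compounds named here, the only step between two compounds that differ in one place is a number 14.5 percentage points higher from compound 2 to compound 3 (beyond the scatter), a modest rise, and it concerns a different exchange on a different part of the shared core.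

Compound 4 `COc1cc(C(=O)N/N=C/c2ccc(F)cc2)cc(OC)c1OC` differs from compound 1 as follows: hydrogen in place of fluoro on an aromatic carbon. Going by the values given here, no measured pair shows this exchange, and the one step given does not bear on it. With nothing to lean on, no step beyond the scatter is expected in this assay, and the expected step from compound 1 to compound 4 is a number 3.7 percentage points lower from compound 1 to compound 4 (within the scatter). Compound 4 is estimated at 40%, with a range from 26% to 54%.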

Compound 4, a percentage reported as inhibition, at one concentration (the size of the read-out at that concentration, not a potency): 82.8%
Beside the measured number, compound 4's estimate is 42.8 percentage points below it; measured number above the stated range.
By their numbers in this assay, from the lowest: compounds 1 and 2 (each within the scatter of the next); then compound 3; then compound 4.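

In this assay, the change from 3,4-difluorophenyl to 4-fluorophenyl gives a number 39.1 percentage points higher from compound 1 to compound 4 (beyond the scatter), so this aromatic carbon, ortho to a fluoro group and meta to a large group, is a sensitive position on the core of compound 1. For the compounds shown here, the only step available before this was a number 14.5 percentage points higher from compound 2 to compound 3 (beyond the scatter), a modest one at a different place on the shared core, whereas this exchange of a single fluoro for hydrogen produces a large one. No measurement shown here accounts for the size of this step.

As far as these compounds go, this is a single pair, so it remains open whether hydrogen in place of fluoro has a similar effect on the core of compound 2. From the compounds shown here alone, it also remains open how an amine or a hydroxyl group on this carbon would compare with hydrogen and fluoro.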